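Naphthalen-2-yl in place of 4-iodophenyl: working notes

The source may report more compounds than this note shows. Statements on the series, on what has been measured and on what is new or still open speak of the compounds shown alone.

In a functional assay on WM 266-4 cells (Homo sapiens) for antiproliferative activity, read by MTT assay, with a stated time of 24 h (on this read-out lower numbers stand for stronger inhibition of growth and higher numbers for weaker inhibition of growth), compound 3 `Ic1ccc(C2CC(c3ccc4c(c3)OCCO4)=NN2c2ccccc2)cc1` gives 3470 nM while compound 2 `COc1ccc(C2CC(c3ccc4c(c3)OCCO4)=NN2c2ccccc2)cc1OC` gives 2160 nM and compound 1 `c1ccc(COc2ccc(C3CC(c4ccc5c(c4)OCCO5)=NN3c3ccccc3)cc2)cc1` gives 1130 nM on the same shared core. Compound 3 therefore stands level with one neighbour and apart from the other.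

The next change leads to compound 4 `c1ccc(N2N=C(c3ccc4c(c3)OCCO4)CC2c2ccc3ccccc3c2)cc1`, with naphthalen-2-yl in place of 4-iodophenyl on a saturated ring carbon. For the measured compounds named here, the closest precedent is the exchange on that same carbon, which gave a 1.6-fold higher number from compound 2 to compound 3 (0.21 log units; within the scatter) as its only measured step. The exchange of iodo for benzyloxy on an aromatic carbon gave the larger 3.1-fold higher number from compound 1 to compound 3 (0.49 log units; beyond the scatter) but lies elsewhere, so it bears on this change less directly. One precedent is thin support, yet no step beyond the scatter is expected, and the estimated step is a 1.4-fold lower number from compound 3 to compound 4 (0.14 log units; within the scatter) in this assay for now. The expected value for compound 4 is 2500 nM within an estimated range of 1000 nM to 6000 nM until measured.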

Compound 4, concentration for 50% growth inhibition: 13900 nM
Estimate against measurement, compound 4: 5.6-fold (0.75 log units) below; measured number above the stated range.
By their numbers in this assay, from the lowest: compounds 1, 2 and 3 (each within the scatter of the next, the first and the last beyond it); then compound 4.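

In this assay the saturated ring carbon proves sensitive to the group it carries: naphthalen-2-yl in place of 4-iodophenyl brings a 4.0-fold higher number from compound 3 to compound 4 (0.60 log units; beyond the scatter), and naphthalen-2-yl in place of 3,4-dimethoxyphenyl brings a 6.4-fold higher number from compound 2 to compound 4 (0.81 log units; beyond the scatter). For the compounds shown here, the one earlier exchange on this carbon stayed within the scatter, so these are the first steps at this position to go beyond it, and both run towards weaker inhibition of growth. Nothing measured on these compounds accounts for the size of these steps.

The compounds shown leave open how this carbon responds to a phenyl group carrying an amine or a carboxylic acid. They also leave open whether a single aromatic ring with a longer chain at this carbon would follow compound 3 or compound 4.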